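Second Chloro on the Core: Expected Cytotoxicity

The source may report more compounds than this note shows. Statements on the series, on what has been measured and on what is new or still open speak of the compounds shown alone.

Compound 2 `ClCc1cccc(Cn2cnc3c(Cl)ncnc32)c1` and compound 1 `ClCc1ccc(Cn2cnc3c(Cl)ncnc32)cc1` share a chlorinated two-ring core joined to a side arm, and differ only in where that arm is attached. In a functional assay on HT-29 cells (Homo sapiens) for cytotoxicity, read by sulforhodamine B assay, with a stated time of 48 h (a lower number here means that less compound is tolerated, a higher number that more compound is tolerated), compound 2 gives only a limit, > 100000 nM, which is a boundary of the measurement rather than a number. For compound 1 the result in this assay is "not determined" (no result reported). Compound 2 therefore sits at the limit of > 100000 nM in this assay, at which 1 of the 2 values shown sits. Going by the values given here, no step between two measured compounds is available, so nothing here shows how any structural change shifts this assay. Compound 3 `ClCc1cccc(Cn2cnc3c(Cl)nc(Cl)nc32)c1` differs from compound 2 by chloro in place of hydrogen on an aromatic carbon. The expectation is that compound 3 stays near the limit, with an estimate of 100000 nM in this assay, ranging from 30000 nM to 300000 nM. The expected step of a number no higher from compound 2 to compound 3 (the limit leaves the size open) is expected to be none beyond the scatter, and the likeliest outcome is again a limit rather than a number.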

Compound 3, concentration lethal to 50% of the cells: > 100000 nM
Compound 3: a limit, no number; the forecaster's own chance of this, stated with the estimate: 70%; the middle value lies on the limit itself.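

In this assay compound 2 and compound 3 both give only a limit, so no step between them can be read: the limit of > 100000 nM in this assay, at which 2 of the 3 values shown sit.

The compounds shown leave open whether chloro in place of hydrogen on an aromatic carbon shifts this result at all.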